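Changing the amide substituent: compound 3 to compound 4

The compounds below may be only part of what the source reports. "The series", "measured", "known", "first", "only" and "open" are said of these compounds alone.

Of the compounds shown here, three have been tested in an assay on HEK293 cells for positive allosteric modulation of metabotropic glutamate receptor 5 (Homo sapiens), read by FLIPR, with a stated time of 1 h (a lower number here means that less compound is needed, a higher number that more compound is needed for the effect), and none gave a number. Compound 1 `COc1ccccc1C#Cc1nc2c(s1)C(=O)NCC2` returns only the assay limit of > 10000 nM. Compound 2 `CN1CCc2nc(C#Cc3cccc(F)c3)sc2C1` likewise gives only a limit, > 10000 nM. Compound 3 `CCC(=O)N1CCc2nc(C#Cc3ccccc3)sc2C1` also stops at a limit, > 10000 nM. Compound 3 thus stands together with the other two at the limit of > 10000 nM in this assay, at which 3 of the 3 values shown sit, with no measured value to rank it against them. Compound 4 `O=C(C1CCC(F)(F)CC1)N1CCc2nc(C#Cc3ccccc3)sc2C1` differs from compound 3 by 4,4-difluorocyclohexyl in place of ethyl on a carbonyl carbon. Within the data shown here, no measured step offers guidance here. A move into the measurable range cannot be ruled out, yet the expectation is for no shift beyond the usual scatter, a step that the limit leaves unreadable from compound 3 to compound 4. Compound 4 is accordingly expected to give about 15000 nM, estimated between 3000 nM and 60000 nM, most likely reported again only as a limit.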

Compound 4, half-maximal effective concentration: 70 nM
Beside the measured number, compound 4's estimate is 210-fold (2.33 log units) above it; the measured number lies below the stated range.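

On the carbonyl carbon, 4,4-difluorocyclohexyl in place of ethyl gives an at least 140-fold lower number from compound 3 to compound 4 (2.15 log units; beyond the scatter) in this assay, so this position can bring the series into the measurable range. Compound 4, at 70 nM, is the first compound shown with a number rather than a limit. The step gives only a minimum size, since its starting point is a limit: the limit of > 10000 nM in this assay, at which 3 of the 4 values shown sit.

On these data alone, whether the shift rests on the six-membered ring or on the fluorine atoms stays open. Plain cyclohexyl, or a longer chain such as n-butyl, on the same carbonyl carbon would separate these two readings.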